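The source may hold more compounds than are shown below. What is called first, only, known or untested is meant among the compounds shown, and "the series" means these compounds.

Compounds measured in a functional assay for antagonist activity at integrin alpha-5/beta-1 (Homo sapiens), read by ELISA; a lower number here means a stronger inhibitor, a higher number a weaker inhibitor:
- compound 1, `Cc1cc(C)c(S(=O)(=O)N[C@@H](CNC(=O)C2=NO[C@@]3(C2)C[C@@H](CNC2N=CC=N2)N(C(=O)OCc2ccccc2)C3)C(=O)O)c(C)c1`, 1200 nM
- compound 2, `Cc1cc(-c2ccccc2)cc(C)c1S(=O)(=O)[C@@H](CNC(=O)C1=NOC2(CCC(CNc3ncc[nH]3)CC2)C1)C(=O)O`, 670 nM
- compound 3, `COC(=O)N1C[C@@]2(CC(C(=O)NC[C@H](NS(=O)(=O)c3c(C)cc(C)cc3C)C(=O)O)=NO2)C[C@H]1CNc1nc2ccccc2[nH]1`, 1.4 nM

Compound 1 gives the highest of the three numbers in this assay. Compound 2 stands nearest to it, and the gap between compound 1 and compound 2 lies within the usual scatter, so nothing separates the two. Compound 3 stands far apart: its number is lower than that of compound 1 by a gap well beyond the scatter, which shows that the shared core can reach very low numbers in this assay.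

Compound 4, `Cc1cc(C)c(S(=O)(=O)N[C@@H](CNC(=O)C2=NO[C@]3(C2)C[C@@H](CNC2N=CC=N2)N(C(=O)OCc2ccccc2)C3)C(=O)O)c(C)c1`, is the next step from compound 1. The change is the two compounds have the same atoms and bonds and differ only in configuration as drawn: 1 of 3 stereo elements differ; a stereocentre at a saturated ring carbon is drawn R in compound 1 and S in compound 4. Going by the values given here, no measured pair in this set differs only in configuration, so no step of this kind is known here. A stereochemical inversion on a ring of this size can leave the number unchanged or move it a long way in either direction. Given that compound 3 reaches 1.4 nM on the same core, the step of a 12-fold lower number from compound 1 to compound 4 (1.08 log units; beyond the scatter) is expected to go toward a lower number, though with wide uncertainty. For compound 4 the estimate in this assay is 100 nM, with a range from 8 nM to 1200 nM.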

Compound 4, half-maximal inhibitory concentration: 13 nM
Beside the measured number, compound 4's estimate is 7.7-fold (0.89 log units) above it; the measured number falls inside the stated range.
By their numbers in this assay, from the lowest: compound 3; then compound 4; then compounds 2 and 1 (each within the scatter of the next).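

Inverting a single stereocentre at a saturated ring carbon, from R to S, gives in this assay a 92-fold lower number from compound 1 to compound 4 (1.97 log units; beyond the scatter), so the number at this position depends strongly on configuration. This step can be assigned to that one stereocentre alone, because nothing else separates the pair: the fact that compounds 1 and 4 differ only in the configuration as drawn. The earlier compounds shown here differed from one another in more than one place, so they could not separate an effect of configuration from that of a change of group, whereas this pair shows that configuration alone, with the benzyloxycarbonyl group and the rest of the structure kept, can produce a step well beyond the scatter.

This remains a single pair, so the compounds shown leave open whether the S configuration gives a step of similar size and direction when the other groups on the shared core change, for example when the benzyloxycarbonyl group gives way to an acetyl group or a free amine. They also leave open how the other two stereo elements of the core contribute, since neither is inverted on its own in any pair here.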